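A few compounds are considered here, and "the series" means these few. Any claim that something is new, unique, unknown or untested is made for them only; others in the source may bear on it.

Working notes on the indole series in an assay on isolated protein for inhibition of Myeloperoxidase (Homo sapiens), read by ELISA, with a stated time of 5 min; a higher number here means a weaker inhibitor, a lower number a stronger inhibitor.

Of the compounds shown here, three sharing one core have been measured. Compound 1 `NC(=O)CCCCc1c[nH]c2ccc(F)cc12` gives 43 nM. Compound 2 `N#CSCCCc1c[nH]c2ccc(F)cc12` gives 23 nM. Compound 3 `NC(=O)CCCc1c[nH]c2ccc(F)cc12` gives 18 nM. On these numbers compound 3 holds the lowest value of the three; its nearest neighbour is compound 2, at a gap that sits within the usual scatter, and its furthest is compound 1, a gap that lies beyond it. The steps read: a 1.9-fold lower number from compound 1 to compound 2 (0.27 log units; within the scatter); a 2.4-fold lower number from compound 1 to compound 3 (0.38 log units; beyond the scatter); a 1.3-fold lower number from compound 2 to compound 3 (0.11 log units; within the scatter).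

Compound 4 `NCCSCCc1c[nH]c2ccc(F)cc12` has not been measured in this assay. Against compound 3 it differs as follows: (2-aminoethyl)sulfanyl in place of carbamoylmethyl on a saturated chain carbon, two bonds along the chain from an aromatic carbon

For the measured compounds named here, of the measured steps, the one from compound 1 to compound 2 is the most informative, since it also exchanged an amide-bearing group for a sulfur-linked one, and it was a 1.9-fold lower number from compound 1 to compound 2 (0.27 log units; within the scatter), within the scatter. The step from compound 2 to compound 3, between a sulfur-linked group and an amide, was likewise within the scatter. Nothing measured here addresses a primary amine on the chain. The expectation for compound 4 is therefore a change of no more than the scatter, a 1.4-fold higher number from compound 3 to compound 4 (0.14 log units; within the scatter), with a wide band for the unknown amine. Compound 4 is estimated at 25 nM, between 7 nM and 90 nM.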

Compound 4, half-maximal inhibitory concentration: 8 nM
For compound 4 the middle estimate is 3.1-fold (0.49 log units) above the measured one; measured number inside the range.
By their numbers in this assay, from the lowest: compound 4; then compounds 3, 2 and 1 (each within the scatter of the next, the first and the last beyond it).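

In this assay, (2-aminoethyl)sulfanyl on a saturated chain carbon, two bonds along the chain from an aromatic carbon, gives steps beyond the scatter against all three earlier compounds: a 2.3-fold lower number from compound 3 to compound 4 (0.35 log units; beyond the scatter), a 2.9-fold lower number from compound 2 to compound 4 (0.46 log units; beyond the scatter) and a 5.4-fold lower number from compound 1 to compound 4 (0.73 log units; beyond the scatter). Among the earlier compounds, only the step between compound 1 and compound 3 lay beyond the scatter, so this chain position had not yet shown a clear separation from both the amide-bearing and cyanosulfanyl compounds, and compound 4 now stands as the strongest inhibitor of the four. No measurement available here accounts for this difference.

Sulfur and the terminal amine enter together in compound 4, so their contributions remain inseparable; an amine on an all-carbon chain would divide them. A longer chain ending in the same amine, or a carboxylic acid in place of the amine, would show how much of the change depends on chain length and on the amine itself.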